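The compounds below may be only part of what the source reports. "The series", "measured", "known", "first", "only" and "open" are said of these compounds alone.

Measured in a functional assay on MDA-MB-231 cells (Homo sapiens), read by microscopy and transwell migration, with a stated time of 24 h; on this read-out higher numbers stand for weaker inhibition and lower numbers for stronger inhibition:
- compound 1 `CCCn1c(-c2ccc(C)cc2C)cs/c1=N\C(=O)c1ccccc1`: 292 nM
- compound 2 `Cn1c(-c2ccccc2Cl)cs/c1=N\C(=O)c1ccccc1`: 268 nM

Compound 2, at 268 nM, stands level with compound 1, at 292 nM: the two numbers lie within the scatter of each other. Compound 3 `Cn1c(-c2cccc(Cl)c2)cs/c1=N\C(=O)c1ccccc1` is the next entry. It has 3-chlorophenyl in place of 2-chlorophenyl on an aromatic carbon, and the rest of the structure stays as in compound 2. Within the data shown here, no pair of measured compounds differs in one place only, so the series offers no direct guide to this change. In this assay only a small shift towards a higher number is expected, scarcely beyond the scatter. The expected step is a 1.2-fold higher number from compound 2 to compound 3 (0.08 log units; within the scatter). Compound 3 is estimated at 320 nM, with an expected range of 110 nM to 900 nM.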

Compound 3, half-maximal inhibitory concentration: 367 nM
Compound 3: the middle estimate sits 1.1-fold (0.06 log units) below what was measured; the range from low to high includes it.
By their numbers in this assay, from the lowest: compounds 2, 1 and 3 (each within the scatter of the next).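

In this assay, 3-chlorophenyl in place of 2-chlorophenyl on the aromatic carbon of the five-membered aromatic ring gives a 1.4-fold higher number from compound 2 to compound 3 (0.14 log units; within the scatter), so the two chlorophenyl groups stand level in this read-out. Among these compounds, this is the only step with one place changed, and it shows that the chlorine can occupy either of these two places on the phenyl group with no difference beyond the scatter. Nothing at hand bears on why the two compounds stand level.

Open, from the compounds shown here alone, is whether this tolerance holds for groups other than chlorine on the phenyl group, such as an amine, a methoxy group or a carboxylic acid. Also open, going by these compounds, is whether the level result persists with a longer chain in place of the methyl group on the ring nitrogen.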